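Substituent swaps at one core carbon, then a thiourea

This account rests on a few compounds, and the source may have more. Where it says the series, first, only, none or still open, it means among the compounds named here.

Compound 1 `N#Cc1c(Cl)nc(SCc2nc3ccccc3[nH]2)nc1-c1ccccc1` gives 3.28 nM in a functional assay on SK-MEL-28 cells (Homo sapiens) for cytotoxicity, read by MTT assay, with a stated time of 3 days; on this read-out higher numbers stand for weaker inhibition and lower numbers for stronger inhibition. Compound 2 `N#Cc1c(NN)nc(SCc2nc3ccccc3[nH]2)nc1-c1ccccc1` gives 3 nM in this assay, and compound 3 `CNc1nc(SCc2nc3ccccc3[nH]2)nc(-c2ccccc2)c1C#N` gives 2.87 nM. Compound 2 therefore sits among three values that all lie within the scatter of one another: a 1.1-fold lower number from compound 1 to compound 2 (0.04 log units; within the scatter), a 1.1-fold lower number from compound 1 to compound 3 (0.06 log units; within the scatter) and a 1.0-fold lower number from compound 2 to compound 3 (0.02 log units; within the scatter). Compound 4 `N#Cc1c(NNC(N)=S)nc(SCc2nc3ccccc3[nH]2)nc1-c1ccccc1` differs from compound 2 by a group of 3 heavy atoms (1 carbon, 1 nitrogen, 1 sulfur; no ring) in place of a hydrogen atom, on an amine nitrogen. Going by the values given here, the step that bears most directly on this change is a 1.0-fold lower number from compound 2 to compound 3 (0.02 log units; within the scatter), which alters the same amine nitrogen; no measured step adds a group of this size there. Given that every exchange at this carbon so far left the number unchanged, the step of a 1.1-fold higher number from compound 2 to compound 4 (0.03 log units; within the scatter) is expected to stay within the scatter. The estimate for compound 4 in this assay is 3.2 nM, with a range from 1.4 nM to 7.5 nM.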

Compound 4, half-maximal inhibitory concentration: 3.2 nM
Estimate against measurement, compound 4: no gap at the digits printed, and the stated range covers the measured number.
By their numbers in this assay, from the lowest: compounds 3, 2, 4 and 1 (each within the scatter of the next).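

A much larger group on the amine nitrogen now proves tolerated in this assay, with the step staying within the scatter (a 1.1-fold higher number from compound 2 to compound 4 (0.03 log units; within the scatter)). The two further comparisons agree (a 1.1-fold higher number from compound 3 to compound 4 (0.05 log units; within the scatter); a 1.0-fold lower number from compound 1 to compound 4 (0.01 log units; within the scatter)), so all four compounds, with chloro, aminoamino, methylamino or this extended group on the aromatic carbon, lie within the scatter of one another. No supporting data explain this flat result.

From the compounds shown here alone, whether a carboxylic acid, a morpholine or a longer alkyl chain on this carbon would also leave the number in place remains open. So does the effect of any change elsewhere on the shared core.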